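A few compounds are considered here, and "the series" means these few. Any claim that something is new, unique, unknown or untested is made for them only; others in the source may bear on it.

Compound 1 `CCCn1c(-c2ccccc2)nc2c(NC3CCC3)ncnc21`: 15 nM
Compound 2 `CCCn1c(-c2ccccc2)nc2c(NC3CCCC3)ncnc21`: 10 nM
Compound 3 `CCCn1c(-c2ccccc2)nc2c(NC3CCCCC3)ncnc21`: 27 nM

These three compounds share one core and differ only in the ring attached to the nitrogen on the aromatic ring. In an assay on CHO cells for displacement of a labelled ligand from adenosine receptor A1 (Homo sapiens), read by scintillation counting, with a stated time of 3 h (on this read-out higher numbers stand for weaker inhibition and lower numbers for stronger inhibition), compound 2 gives the lowest of the three numbers. Its gap to compound 1, a 1.5-fold lower number from compound 1 to compound 2 (0.18 log units; within the scatter), is within the scatter, so compounds 1 and 2 cannot be set in order; its gap to compound 3, a 2.7-fold higher number from compound 2 to compound 3 (0.43 log units; beyond the scatter), is beyond the scatter, and a 1.8-fold higher number from compound 1 to compound 3 (0.26 log units; within the scatter) is within it.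

Compound 4 `CCn1c(-c2ccccc2)nc2c(NC3CCCC3)ncnc21` differs from compound 2 by hydrogen in place of methyl on a saturated chain carbon, two bonds along the chain from an aromatic nitrogen. Within the data shown here, none of the measured steps touches this chain; all of them change the ring on the nitrogen, so there is no measured step that bears directly on this change, and the three measured values stay close to one another throughout. The expectation is therefore a step in this assay of no more than the usual scatter, with no clear direction: a 1.2-fold higher number from compound 2 to compound 4 (0.08 log units; within the scatter). Compound 4 is expected to give 12 nM in this assay, within a range from 4 nM to 35 nM.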

Compound 4, inhibition constant: 3.9 nM
Compound 4: middle estimate off by 3.1-fold (0.49 log units), on the high side; measured number outside the range, below it.
By their numbers in this assay, from the lowest: compound 4; then compounds 2, 1 and 3 (each within the scatter of the next, the first and the last beyond it).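

In this assay, hydrogen in place of methyl on a saturated chain carbon, two bonds along the chain from an aromatic nitrogen, turns propyl into ethyl and gives a 2.6-fold lower number from compound 2 to compound 4 (0.41 log units; beyond the scatter). Among these compounds, the earlier compounds varied only the ring on the other nitrogen, so this is the first sign that this chain also affects the result, and here the shorter chain goes with stronger inhibition. Nothing available explains why removing this one carbon has this effect.

The compounds shown leave open whether the trend continues in either direction, to a methyl group or to a longer chain such as butyl, or how a chain ending in an amine would behave. They also leave open whether propyl to ethyl gives a similar step when cyclobutyl or cyclohexyl replaces cyclopentyl.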